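Cytotoxicity notes: methylsulfanyl for methyl on compound 1

The source may hold more compounds than are shown below. What is called first, only, known or untested is meant among the compounds shown, and "the series" means these compounds.

Compound 1 `Cc1cccc(C(=O)N2CCCC(C(=O)Nc3ccc(Cl)cc3)C2)c1` gives 0% in an ADME assay on PC-3 cells (Homo sapiens) for cytotoxicity, read by WST assay, tested at 100 uM (a higher number here means more inhibition at the concentration tested (going by the name of the read-out), a lower number less inhibition), level with compound 2 `O=C(Nc1cccc(Oc2ccccn2)c1)C1CCCN(C(=O)c2cc(C(F)(F)F)cc(C(F)(F)F)c2)C1` at 0% at the digits shown. Compound 3 `O=C(Nc1cccc(OCCc2ccccn2)c1)C1CCCN(C(=O)c2cc(C(F)(F)F)cc(C(F)(F)F)c2)C1` gives 5%. Among the compounds with values here, the only measured step, a number 5 percentage points higher from compound 2 to compound 3 (within the scatter), is within the scatter. Compound 4 `CSc1cccc(C(=O)N2CCCC(C(=O)Nc3ccc(Cl)cc3)C2)c1` differs from compound 1 by methylsulfanyl in place of methyl on an aromatic carbon. Within the data shown here, no measured step touches this position, and the single measured step, between two ether substituents, stayed within the scatter, while all three measured compounds sit near the floor of this assay. The expected step is therefore a number 3 percentage points higher from compound 1 to compound 4 (within the scatter), none beyond the scatter. Compound 4 is estimated at 3%, with a range from 0% to 15%.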

Compound 4, a percentage reported as inhibition, at one concentration (the size of the read-out at that concentration, not a potency): 0%
Compound 4: middle estimate off by 3 percentage points, on the high side, within the range that was stated.
By their numbers in this assay, from the lowest: compounds 1, 2, 4 and 3 (each within the scatter of the next).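

Within the data shown here, the step of no change at the digits printed from compound 1 to compound 4 (within the scatter) in this assay is the first reading at this position, and it places methylsulfanyl and methyl on this aromatic carbon within the scatter of each other. The added sulfur and hydrogen-bond acceptor therefore bring no readable difference here, although both compounds sit at the floor of the read-out, where a drop could not show. Nothing available accounts for this result.

Still open, from the compounds shown here alone, is whether an amine or a carboxylic acid on this aromatic carbon would give a reading beyond the scatter in this assay and whether a longer chain, such as ethylsulfanyl, would do so.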